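The source may report more compounds than this note shows. Statements on the series, on what has been measured and on what is new or still open speak of the compounds shown alone.

Compound 2 `COc1ccccc1N1C(=O)/C(=C/c2ccc(OCc3ccc(C(=O)O)cc3)cc2)SC1=S` gives 2000 nM in an assay on isolated protein for inhibition of Apoptosis regulator Bcl-2 (Homo sapiens), read by fluorescence polarization (a lower number here means a stronger inhibitor, a higher number a weaker inhibitor), and stands at the lowest of the two numbers in hand. Compound 3 `COc1ccccc1N1C(=O)/C(=C/c2ccc(OCC(=O)Nc3ccc(C(=O)O)cc3)cc2)SC1=S` gives 10000 nM in this assay, so that a 5.0-fold higher number from compound 2 to compound 3 (0.70 log units; beyond the scatter). Compound 1 `O=C(Nc1ccc(O)c(C(=O)O)c1)c1ccc(/C=C2\SC(=S)N(c3ccccc3)C2=O)cc1` gives only a limit in this assay, > 10000 nM (the limit of > 10000 nM in this assay, at which 1 of the 3 values shown sits). For the measured compounds named here, compound 1 differs from compound 2 in more than one place, so its limit marks no single step.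

Compound 4 `Cc1cccc(N2C(=O)/C(=C/c3ccc(OCc4ccc(C(=O)O)cc4)cc3)SC2=S)c1` is not yet measured. It differs from compound 2 by 3-methylphenyl in place of 2-methoxyphenyl on an amide-type nitrogen in a ring. Going by the values given here, no measured step bears on the group on the amide-type nitrogen in the ring: the only measured step, a 5.0-fold higher number from compound 2 to compound 3 (0.70 log units; beyond the scatter), concerns a different part of the shared core, and compound 1 adds nothing on this point. Without a precedent for this change, the step is expected to remain within the scatter, a 1.3-fold higher number from compound 2 to compound 4 (0.10 log units; within the scatter). Compound 4 is therefore estimated at about 2500 nM in this assay, with a range from 800 nM to 8000 nM.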

Compound 4, inhibition constant: > 10000 nM
Compound 4: a limit, no number (the forecaster's own chance of this, stated with the estimate: 15%); middle value at least 4.0-fold (0.60 log units) away from the limit.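

Exchanging 2-methoxyphenyl for 3-methylphenyl on the amide-type nitrogen in the ring gives an at least 5.0-fold higher number from compound 2 to compound 4 (0.69 log units; beyond the scatter) in this assay, so the group at this position is not neutral for the series. The earlier compounds shown here offered one readable step, a 5.0-fold higher number from compound 2 to compound 3 (0.70 log units; beyond the scatter), and that step concerned a different part of the shared core. Compound 4 gives a limit and not a number, so this step fixes only a minimum size: the limit of > 10000 nM in this assay, at which 2 of the 4 values shown sit.

The compounds shown do not separate the exchange of methoxy for methyl from the difference between the 2- and 3-substituted phenyl groups; a 2-methylphenyl or 3-methoxyphenyl group on the same nitrogen would tell these apart. Also open, going by these compounds, is whether any group at this position gives a number below that of compound 2, 2000 nM.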